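Swapping the aryl group of compound 3: an expected step

The source may report more compounds than this note shows. Statements on the series, on what has been measured and on what is new or still open speak of the compounds shown alone.

Measured so far:
- compound 1, `COc1ccccc1Oc1c(N)nc(-c2cccc(C)c2)nc1Cl`: 13100 nM
- compound 2, `COc1ccccc1Oc1c(N)nc(-c2ccc(Cl)cc2)nc1Cl`: 18800 nM
- compound 3, `COc1ccccc1Oc1c(N)nc(-c2cccc(C)c2)nc1OCCO`: 70900 nM

Of the compounds shown here, three sharing one core have been tested in a functional assay on B16 cells (Mus musculus) for cytotoxicity, read by CCK-8 assay, with a stated time of 24 h; a lower number here means a stronger inhibitor, a higher number a weaker inhibitor. Compound 3 stands highest of the three numbers: compound 2 gives 18800 nM and compound 3 gives 70900 nM, a gap beyond the scatter, and the step of a 5.4-fold higher number from compound 1 to compound 3 (0.73 log units; beyond the scatter) is also beyond the scatter, so compound 3 is the weakest inhibitor of the three by this assay.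

Compound 4, `COc1ccccc1Oc1c(N)nc(-c2ccc(I)cc2)nc1OCCO`, has not yet been measured in this assay. It differs from compound 3 in one place: 4-iodophenyl in place of 3-methylphenyl on an aromatic carbon.

Going by the values given here, only one measured step bears on this change. The step of a 1.4-fold higher number from compound 1 to compound 2 (0.16 log units; within the scatter) exchanged the same 3-methylphenyl for a 4-chlorophenyl on the same aromatic carbon and stayed within the scatter. Among the compounds with values here, a 4-iodophenyl is a different halogen, so the comparison is imperfect, but nothing among the measured compounds points to a large step. Compound 4 is therefore expected to give a number near that of compound 3, with the step of a 1.1-fold higher number from compound 3 to compound 4 (0.05 log units; within the scatter) expected to lie within the scatter. The estimate for compound 4 in this assay is 80000 nM, with a range from 30000 nM to 200000 nM.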

Compound 4, half-maximal inhibitory concentration: 19600 nM
Estimate against measurement, compound 4: 4.1-fold (0.61 log units) above, outside the stated range (below it).
By their numbers in this assay, from the lowest: compounds 1, 2 and 4 (each within the scatter of the next); then compound 3.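

In this assay, the carbon between two ring nitrogen atoms proves able to carry a change beyond the scatter, with 4-iodophenyl in place of 3-methylphenyl giving a 3.6-fold lower number from compound 3 to compound 4 (0.56 log units; beyond the scatter) in the series with the 2-hydroxyethoxy group. The only earlier exchange at this carbon, made in the series with chloro at that other place, gave a 1.4-fold higher number from compound 1 to compound 2 (0.16 log units; within the scatter) and so had shown no clear response to the aryl group. The two exchanges differ both in the halogen and in the neighbouring group on the shared core, so the data cannot say which of these sets them apart, and no measurement at hand accounts for the new step.

The compounds shown leave open whether the step belongs to the iodine itself or to moving the substituent around the phenyl ring, a question that a 4-methylphenyl or 3-iodophenyl group on the 2-hydroxyethoxy series would address. They also leave open how this carbon would respond to a phenyl ring bearing an amine or a carboxylic acid, and whether a longer chain in place of the 2-hydroxyethoxy group would change the picture.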